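Swapping the chain on the ring nitrogen: allyl to isopropyl

The source may hold more compounds than are shown below. What is called first, only, known or untested is meant among the compounds shown, and "the series" means these compounds.

Compound 1 `CC(C)CNc1nnc(SCC(=O)N(Cc2cccc([N+](=O)[O-])c2)c2ccc(F)cc2)s1`: 36%
Compound 2 `COCCNc1nnc(SCC(=O)N(Cc2cccc([N+](=O)[O-])c2)c2ccc(F)cc2)s1`: 38.6%
Compound 3 `C=CCNc1nnc(SCC(=O)N(Cc2cccc([N+](=O)[O-])c2)c2ccc(F)cc2)s1`: 38.1%

Three compounds share one core and differ only in the chain attached to a nitrogen on an aromatic ring. In an assay on isolated protein for inhibition of Amine oxidase [flavin-containing] B (Homo sapiens), read by fluorescence and Amplex Red, with a stated time of 30 min, tested at 1 mM (on this read-out higher numbers stand for a stronger effect at the one concentration tested and lower numbers for a weaker effect), compound 3 gives 38.1%, the second highest of the three numbers, but its distances to the other two are within the scatter: a number 0.5 percentage points lower from compound 2 to compound 3 (within the scatter) and a number 2.1 percentage points higher from compound 1 to compound 3 (within the scatter), so the three cannot be put in any order.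

Compound 4 `CC(C)Nc1nnc(SCC(=O)N(Cc2cccc([N+](=O)[O-])c2)c2ccc(F)cc2)s1` has not yet been measured. It carries the change (isopropyl in place of allyl on a nitrogen on an aromatic ring). Among the compounds with values here, no measured pair shows exactly this change, yet every change tried at this position, including a number 2.6 percentage points higher from compound 1 to compound 2 (within the scatter), stayed within the scatter. The chain here seems to matter little, so for compound 4 the expected step of a number 0.1 percentage points lower from compound 3 to compound 4 (within the scatter) in this assay is none beyond the scatter. Compound 4 is therefore estimated at 38%, with a likely range from 28% to 48%.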

Compound 4, a percentage reported as inhibition, at one concentration (the size of the read-out at that concentration, not a potency): 36%
The estimate for compound 4 lay 2 percentage points above the measured number; measured number inside the range.
By their numbers in this assay, from the lowest: compounds 1, 4, 3 and 2 (each within the scatter of the next).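

In this assay, isopropyl in place of allyl removes the double bond while keeping three carbons, and the result is a number 2.1 percentage points lower from compound 3 to compound 4 (within the scatter). The other two swaps to isopropyl at this nitrogen behave alike: 2-methoxyethyl gives a number 2.6 percentage points lower from compound 2 to compound 4 (within the scatter), and isobutyl gives no change at the digits printed from compound 1 to compound 4 (within the scatter), so these four chains cannot be told apart on this read-out. Nothing available explains why they read alike.

Still open, going by these compounds, is whether a chain carrying an amine or a carboxylic acid, a much longer chain, or a phenyl ring on this nitrogen would shift the number beyond the scatter. These percentages also come from a single concentration, so they give no potency for any of the four compounds.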